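A Second Fluorine on the Benzylamine Arm

The source may report more compounds than this note shows. Statements on the series, on what has been measured and on what is new or still open speak of the compounds shown alone.

Measured compounds:
- compound 1 `Nc1c(C(=O)O)cnn1-c1ccc(CN(Cc2ccc(F)cc2)Cc2ccc(Cl)cc2)cc1`: 3 mL.min-1.g-1
- compound 2 `COc1ccc(C(Cc2ccc(-n3ncc(C(=O)O)c3N)cc2)c2nc(-c3cccc(F)c3)no2)cc1`: 3 mL.min-1.g-1

Two compounds have been run in an ADME assay on liver (Rattus norvegicus) for metabolic stability, read by LC-MS, using microsomes and NADPH, with stated times of 5 min and 30 min, tested at 1 uM; on this read-out higher numbers stand for fast clearance and lower numbers for slow clearance. In this assay compound 1 gives 3 mL.min-1.g-1, and compound 2 gives 3 mL.min-1.g-1. Compound 1 therefore stands level with compound 2 at the digits shown; the two values lie within the usual scatter of this read-out, so nothing can be said about an order between them.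

The next compound, compound 3 `Nc1c(C(=O)O)cnn1-c1ccc(CN(Cc2ccc(Cl)cc2)Cc2ccc(F)c(F)c2)cc1`, has not yet been measured. It is reached from compound 1 by a single change: fluoro in place of hydrogen on an aromatic carbon. Read one bond further out, the 4-fluorobenzyl group of compound 1 becomes a 3,4-difluorobenzyl group in compound 3, with the rest of the molecule untouched.

Within the data shown here, no pair of measured compounds shows what this change does in this assay, so the expectation rests only on the value of compound 1 and on the small size of the change. For compound 3 the step of no change at the digits printed from compound 1 to compound 3 (within the scatter) is expected to stay within the scatter, in no clear direction. The clearance of compound 3 is estimated at 3 mL.min-1.g-1, with a range from 1.5 mL.min-1.g-1 to 6 mL.min-1.g-1.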

Compound 3, intrinsic clearance in microsomes: 2 mL.min-1.g-1
The estimate for compound 3 lay 1.5-fold (0.18 log units) above the measured number; the measured number falls inside the stated range.
By their numbers in this assay, from the lowest: compounds 3, 1 and 2 (each within the scatter of the next).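

Among these compounds, this is the first step in this assay that isolates a single change: fluoro in place of hydrogen on an aromatic carbon, turning the 4-fluorobenzyl group into a 3,4-difluorobenzyl group, gives a 1.5-fold lower number from compound 1 to compound 3 (0.18 log units; within the scatter). The read-out therefore does not separate the two compounds, and on this one example a second fluoro at this place, ortho to a fluoro group, leaves clearance in rat liver microsomes indistinguishable from that of the parent. Nothing available bears on why the number behaves this way.

Fluoro is the only group shown entering at this place, so it remains open how a larger or different substituent there, such as a methoxy, a nitrile, an amine or a trifluoromethyl, would read in this assay. The chlorine-bearing benzyl arm and the carboxylic acid also stand unchanged in compound 1 and compound 3, which leaves open what an amide in place of that acid, or another group on that arm, would do to the number.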